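Methyl for chloro on the outer dichlorophenyl amide

The compounds below may be only part of what the source reports. "The series", "measured", "known", "first", "only" and "open" are said of these compounds alone.

Among the compounds with values here, compound 1 `O=C(Nc1ccc(Cl)c(C(=O)Nc2ccc(-c3ncc[nH]3)nc2)c1)c1ccc(Cl)c(Cl)c1` is the weaker of the two compounds measured so far. In a functional assay on HepG2 cells (Homo sapiens) for cytotoxicity, read by MTT assay, with a stated time of 72 h (a lower number here means a stronger inhibitor, a higher number a weaker inhibitor), compound 1 gives 15200 nM, the higher of the two numbers, and compound 2 `O=C(Nc1ccc(Cl)c(Cl)c1)c1ccc(Cl)c(C(=O)Nc2ccc(-c3ncc[nH]3)nc2)c1` gives 3970 nM, a gap beyond the usual scatter. Compound 3 `Cc1cc(C(=O)Nc2ccc(Cl)c(C(=O)Nc3ccc(-c4ncc[nH]4)nc3)c2)ccc1Cl` differs from compound 1 in one exchange: methyl in place of chloro on an aromatic carbon. Within the data shown here, no measured pair shows this exchange, so compound 1 is the only anchor, and the expected step is within the scatter in either direction. Compound 3 is therefore estimated at 16000 nM, within 5000 nM to 45000 nM. That estimate corresponds to an expected step of a 1.1-fold higher number from compound 1 to compound 3 (0.02 log units; within the scatter).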

Compound 3, half-maximal inhibitory concentration: 11500 nM
Beside the measured number, compound 3's estimate is 1.4-fold (0.14 log units) above it; the measured number falls inside the stated range.
By their numbers in this assay, from the lowest: compound 2; then compounds 3 and 1 (each within the scatter of the next).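

In this assay the exchange of 3,4-dichlorophenyl for 4-chloro-3-methylphenyl gives a 1.3-fold lower number from compound 1 to compound 3 (0.12 log units; within the scatter) and so leaves the number unchanged within the scatter. Within the data shown here, this is the first single exchange read at this position, ortho to a chloro group, and it shows that methyl can stand in place of chloro here with no measurable change in this assay. No available measurement offers an explanation for this result. The compounds shown leave open whether an amine or a carboxylic acid at this position would shift the number.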